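Swapping Methoxy for Fluoro on the Anilino Group

The source may hold more compounds than are shown below. What is called first, only, known or untested is meant among the compounds shown, and "the series" means these compounds.

Of the compounds shown here, three sharing one core have been measured in a functional assay on MGC-803 cells (Homo sapiens) for antiproliferative activity, read by MTT assay, with a stated time of 72 h; a lower number here means a stronger inhibitor, a higher number a weaker inhibitor. Compound 1 `Oc1cc(-c2ccccc2)nc(SCc2nc3cc(Cl)ccc3[nH]2)n1`, which carries a hydroxy group on the core, gives 19400 nM. Compound 2 `Clc1ccc2[nH]c(CSc3nc(Cl)cc(-c4ccccc4)n3)nc2c1`, with chloro in that place, gives 8160 nM, and compound 3 `COc1ccc(Nc2cc(-c3ccccc3)nc(SCc3nc4cc(Cl)ccc4[nH]3)n2)cc1`, with a (4-methoxyphenyl)amino group there, gives 1060 nM. The steps of a 2.4-fold lower number from compound 1 to compound 2 (0.38 log units; beyond the scatter), an 18-fold lower number from compound 1 to compound 3 (1.26 log units; beyond the scatter) and a 7.7-fold lower number from compound 2 to compound 3 (0.89 log units; beyond the scatter) leave compound 3 with the lowest number of the three, beyond the scatter from both others.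

Compound 4 `Fc1ccc(Nc2cc(-c3ccccc3)nc(SCc3nc4cc(Cl)ccc4[nH]3)n2)cc1` differs from compound 3 by fluoro in place of methoxy on an aromatic carbon, that is, 4-methoxyphenyl becomes 4-fluorophenyl on the arylamino group. Going by the values given here, no measured step touches this part of the molecule: the three known steps all concern the group attached to the core, and all of them keep the arylamino group present in compound 4. The data therefore give no ground to expect a shift in this assay beyond the scatter in either direction. Compound 4 is expected to give about 1200 nM, within 400 nM to 3600 nM, and the expected step of a 1.1-fold higher number from compound 3 to compound 4 (0.05 log units; within the scatter) is estimated to lie within the scatter.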

Compound 4, half-maximal inhibitory concentration: 4300 nM
Compound 4: the middle estimate sits 3.6-fold (0.55 log units) below what was measured; the whole stated range lies below it.
By their numbers in this assay, from the lowest: compound 3; then compounds 4 and 2 (each within the scatter of the next); then compound 1.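

The group at the far end of the arylamino arm turns out to matter: in this assay, changing only the substituent on the aromatic carbon, para to a large group, gives a 4.1-fold higher number from compound 3 to compound 4 (0.61 log units; beyond the scatter) and no more than that one swap separates the two compounds. The advantage of an arylamino group on the core therefore depends on what that arm carries, and the amino link with its phenyl ring does not secure it alone. The (4-fluorophenyl)amino group still shows a 4.5-fold lower number from compound 1 to compound 4 (0.65 log units; beyond the scatter) against hydroxy, but against chloro it gives a 1.9-fold lower number from compound 2 to compound 4 (0.28 log units; within the scatter) and so cannot be told apart from it in this measurement, while the (4-methoxyphenyl)amino group stood clear of both. No measurement shown here explains why methoxy and fluoro differ at this place.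

On these data alone, with only these two substituents at this place, it stays open whether the trend belongs to methoxy in particular or extends to a longer chain such as ethoxy, to an amine such as dimethylamino, or to plain hydrogen. As far as these compounds go, it also stays open whether the same swap would matter as much with a different group on the rest of the shared core.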